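A few compounds are considered here, and "the series" means these few. Any claim that something is new, unique, unknown or untested is made for them only; others in the source may bear on it.

Measured so far in a functional assay on Huh-7 cells (Homo sapiens) for cytotoxicity, read by MTT assay, with a stated time of 72 h; a higher number here means that more compound is tolerated, a lower number that less compound is tolerated:

Compound 1, `CS(=O)(=O)N1CCC2(CC1)OOC1(CCCC1)OO2`, gives > 100 ug/mL, which is a limit of the assay rather than a number.
Compound 2, `CS(=O)(=O)N1CCC2(CC1)OOC1(CCCCC1)OO2`, gives > 100 ug/mL, again only a limit.
Compound 3, `CCS(=O)(=O)N1CCC2(CC1)OOC1(CCCC1)OO2`, gives > 100 ug/mL, also a limit.

Compound 1 and compound 3 share a core and differ in one place, (methyl in place of hydrogen on a saturated chain carbon bound to a sulfonyl sulfur). What this change did to tolerance cannot be read: the outcome is a step that the two limits leave unreadable from compound 1 to compound 3, because both compounds sit at the limit of > 100 ug/mL in this assay, at which 3 of the 3 values shown sit. Compound 2 carries a different core from compound 1; how the two cores differ is not broken down here.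

Compound 4, `CCS(=O)(=O)N1CCC2(CC1)OOC1(CCCCC1)OO2`, has not yet been measured in this assay. It stands to compound 2 as compound 3 stands to compound 1, the same change in the same place: methyl in place of hydrogen on a saturated chain carbon bound to a sulfonyl sulfur. On the pair already measured this change left both partners at the limit. Compound 2, the starting point for compound 4, also sits at the limit. The expected step is a step that the limit leaves unreadable from compound 2 to compound 4, meaning no readable change in tolerance is expected. This rests on compound 3, whose value > 100 ug/mL is a limit. It rests equally on compound 1, whose value > 100 ug/mL is a limit. Compound 4 is therefore expected to be tolerated at about 150 ug/mL, in a range from 100 ug/mL to 300 ug/mL, and most likely to be reported only as a limit once more.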

Compound 4, half-maximal cytotoxic concentration: > 100 ug/mL
Compound 4 ended at the assay's limit; the forecaster's own chance of this, stated with the estimate: 85%; the middle value lies beyond the limit too.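

No step can be read from compound 2 to compound 4, or between any other pair here, since each compound gives a limit rather than a number: the limit of > 100 ug/mL in this assay, at which 4 of the 4 values shown sit.

The compounds shown leave open at what concentration any of them would become cytotoxic in this assay, and whether the change from methylsulfonyl to ethylsulfonyl or the difference between the two cores alters tolerance at all.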